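Fluoro to methoxy on a second core, carried over

This account rests on a few compounds, and the source may have more. Where it says the series, first, only, none or still open, it means among the compounds named here.

Three compounds of the series have a number in a functional assay on the whole organism (strain Wistar albino) for inhibition, with Rattus norvegicus as the target, read by paw edema, with stated times of 1 h and 3 h, at a dose of 0.32 mmol/kg by the intraperitoneal route; on this read-out higher numbers stand for more inhibition at the one dose given (going by the name of the read-out) and lower numbers for less inhibition. Compound 1 `COc1ccc(-c2nn(-c3ccc(S(N)(=O)=O)cc3)cc2C(CC(=O)c2ccc(Cl)cc2)C(=O)c2ccc(F)cc2)cc1` gives 68.1% in this assay. Compound 2 `COc1ccc(C(=O)C(CC(=O)c2ccc(Cl)cc2)c2cn(-c3ccc(S(N)(=O)=O)cc3)nc2-c2ccc(OC)cc2)cc1` gives 22.5% in this assay. The two differ in one place, (methoxy in place of fluoro on an aromatic carbon), and that change produced a number 45.6 percentage points lower from compound 1 to compound 2 (beyond the scatter).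

Compound 3 `COc1ccc(-c2nn(-c3ccc(S(N)(=O)=O)cc3)cc2-c2cc(-c3ccc(Cl)cc3)[nH]c2-c2ccc(F)cc2)cc1` is built on a different core; the difference between the core of compound 1 and the core of compound 3 is not broken down here. In this assay compound 3 gives 55.9%, which is lower than compound 1 and higher than compound 2.

Compound 4 `COc1ccc(-c2nn(-c3ccc(S(N)(=O)=O)cc3)cc2-c2cc(-c3ccc(Cl)cc3)[nH]c2-c2ccc(OC)cc2)cc1` is not yet measured. It differs from compound 3 by methoxy in place of fluoro on an aromatic carbon. This is the same change as the one made from compound 1 to compound 2, made twice among the compounds shown, and the place is described in the same words both times. Whether the step carries over from the core of compound 1 to the core of compound 3 is not shown by any measured pair; the only guide is the single step seen on the first core.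

Among the measured compounds shown here, the expectation for compound 4 is therefore a drop, estimated as a number 27.9 percentage points lower from compound 3 to compound 4 (beyond the scatter) in this assay, somewhat smaller than the measured step due to a number 45.6 percentage points lower from compound 1 to compound 2 (beyond the scatter) being the only instance and the core being different. Compound 4 is expected to give about 28% in this assay, with the range 10% to 48%.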

Compound 4, a percentage reported as inhibition, in the whole organism at one dose (the size of the read-out at that dose, not a potency): 28.6%
For compound 4 the middle estimate is 0.6 percentage points below the measured one, and the stated range covers the measured number.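

In this assay the change from 4-fluorophenyl to 4-methoxyphenyl on the second core gives a number 27.3 percentage points lower from compound 3 to compound 4 (beyond the scatter) and so runs in the same direction as on the first core, which means that the sign of the step carries over between the two cores shown. The size of the step does not carry over, and the two steps stand clearly apart: the same change on two cores in this assay, a number 45.6 percentage points lower (beyond the scatter) from compound 1 to compound 2 and a number 27.3 percentage points lower (beyond the scatter) from compound 3 to compound 4, 18.3 percentage points apart, beyond the scatter of two such steps. With one pair on each core, the data show neither why the size differs nor whether the direction would hold on a further core, and a percentage at one dose gives no potency for either pair.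

At this place on an aromatic carbon, only fluoro and methoxy are shown, so it remains open whether the number follows any trend across other groups, such as an amine, a carboxylic acid or a longer alkoxy chain. It is also open whether the gap between the two steps would stay the same if the 4-chlorophenyl group or the sulfonamide, both common to all the compounds shown, were replaced.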